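This account rests on a few compounds, and the source may have more. Where it says the series, first, only, none or still open, it means among the compounds named here.

In an ADME assay on L6 cells (Rattus norvegicus) for cytotoxicity (a lower number here means a stronger inhibitor, a higher number a weaker inhibitor), compound 1 `c1ccc2[nH]c(-c3ccc4oc(-c5ccc(C6=NCCN6)cc5)cc4c3)nc2c1` gives 6100 nM and compound 2 `N=C(N)c1ccc(-c2cc3ccc(C(=N)N)cc3o2)cc1` gives 800 nM as its reading. Compound 3 `COc1cc(C(=N)N)ccc1-c1cc2ccc(C(=N)N)cc2o1` gives 108000 nM here, the highest number of the three and so the weakest inhibitor of the set. Within the data shown here, putting methoxy in place of hydrogen on an aromatic carbon produced a 140-fold higher number from compound 2 to compound 3 (2.13 log units; beyond the scatter) in this assay as the one measured single change. Compound 4 `N=C(N)c1ccc(-c2cc3ccc(C(=N)N)cc3o2)c(O)c1` arises from compound 3 through a small edit, methoxy to hydroxy, counted as hydrogen in place of methyl on an oxygen on an aromatic ring in full. Compound 4 keeps the oxygen that compound 2 lacks but loses the methyl, so it sits structurally between the two. Among the measured compounds shown here, no measurement shows this exact change, and that single large step is the only guide. A partial return towards the lower number of compound 2 therefore seems likely, clearly beyond the scatter but smaller than that step. The expected change is a 5.4-fold lower number from compound 3 to compound 4 (0.73 log units; beyond the scatter) as an estimate. Compound 4 is estimated at 20000 nM with an expected range from 3000 nM to 90000 nM in this assay.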

Compound 4, half-maximal inhibitory concentration: > 221000 nM
Compound 4 gave a limit, no number; the forecaster's own chance of this, stated with the estimate: 5%; middle value at least 11-fold (1.04 log units) from the limit.
By their numbers in this assay, from the lowest: compound 2; then compound 1; then compound 3. At a limit, above all of these: compound 4.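

Compound 4 gives no number in this assay, only a limit: the limit of > 221000 nM in this assay, at which 1 of the 4 values shown sits. Hydrogen in place of methyl on the oxygen did not bring the reading back towards that of compound 2, and instead gave an at least 2.0-fold higher number from compound 3 to compound 4 (0.31 log units; beyond the scatter) in the same direction as the earlier rise. The added hydroxy gave an at least 270-fold higher number from compound 2 to compound 4 (2.44 log units; beyond the scatter) as well, so at this position the large rise is seen with the oxygen whether or not the methyl is present.

As far as these compounds go, since compound 4 gave a limit, how far its true value lies beyond it stays open. From the compounds shown here alone, whether the rise needs an oxygen at all also stays open, and an amine or a fluorine on the same aromatic carbon would test this.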